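The source may report more compounds than this note shows. Statements on the series, on what has been measured and on what is new or still open speak of the compounds shown alone.

Measured so far in a functional assay on Ehrlich cells (Mus musculus) for antiproliferative activity, read by trypan blue exclusion, with a stated time of 2 h, tested at 100 ug/mL; a higher number here means a stronger effect of the compound at the concentration tested, a lower number a weaker effect:
Compound 1 `N#CC1=C(N)N(c2ccc(S(N)(=O)=O)cc2)C2=C(C(=O)CCC2)C1c1ccccc1` gives 40%.
Compound 2 `COc1cc(CC2C(C#N)=C(N)N(c3ccc(S(N)(=O)=O)cc3)C3=C2C(=O)CCC3)ccc1O` gives 100%.
Compound 3 `N#CC1=C(N)N(c2ccc(S(N)(=O)=O)cc2)C2=C(C(=O)CCC2)C1c1c(O)ccc2ccccc12` gives 15%.

Compound 3 stands lowest of the three numbers in this assay. The nearest of the other two is compound 1: a number 25 percentage points lower from compound 1 to compound 3 (beyond the scatter). The furthest is compound 2: a number 85 percentage points lower from compound 2 to compound 3 (beyond the scatter).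

Compound 4 `Cc1ccoc1C1C(C#N)=C(N)N(c2ccc(S(N)(=O)=O)cc2)C2=C1C(=O)CCC2` differs from compound 3 in one place: 3-methylfuran-2-yl in place of 2-hydroxynaphthalen-1-yl on a saturated ring carbon. The same saturated ring carbon carries phenyl in compound 1, 4-hydroxy-3-methoxybenzyl in compound 2 and 2-hydroxynaphthalen-1-yl in compound 3. Both measured steps that end in compound 3 run downward, one modest, a number 25 percentage points lower from compound 1 to compound 3 (beyond the scatter), and one large, a number 85 percentage points lower from compound 2 to compound 3 (beyond the scatter). Among the compounds with values here, no compound with 3-methylfuran-2-yl at this position has been measured, so no direct analogue fixes the size of the step. The closest guide is compound 1, which carries a single aromatic ring at this carbon and gives 40%; the step of a number 25 percentage points lower from compound 1 to compound 3 (beyond the scatter) suggests that replacing the two-ring group by a single five-membered aromatic ring should recover activity toward that level, while the large rise seen for compound 2 is not expected here.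

Compound 4 is therefore estimated at 40%, with a range from 15% to 70%. The step expected from compound 3 is a number 25 percentage points higher from compound 3 to compound 4 (beyond the scatter), upward and beyond the scatter.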

Compound 4, a percentage reported as activity, at one concentration (the size of the read-out at that concentration, not a potency): 45%
Compound 4: middle estimate off by 5 percentage points, on the low side, and the stated range covers the measured number.
By their numbers in this assay, from the lowest: compound 3; then compounds 1 and 4 (each within the scatter of the next); then compound 2.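

In this assay, 3-methylfuran-2-yl on the saturated ring carbon shows a number 30 percentage points higher from compound 3 to compound 4 (beyond the scatter) and also a number 5 percentage points higher from compound 1 to compound 4 (within the scatter) so this single five-membered aromatic ring with one hetero atom and phenyl are not told apart at this position. The third step is a number 55 percentage points lower from compound 2 to compound 4 (beyond the scatter) and it leaves 4-hydroxy-3-methoxybenzyl alone at the top of the four compounds, so a change of aromatic ring at this carbon does not by itself reproduce the number of compound 2. A hydroxyl on the group does not track the read-out either: 3-methylfuran-2-yl carries none and stands above 2-hydroxynaphthalen-1-yl, while the hydroxyl-bearing groups of compound 2 and compound 3 lie at the two ends of the series, and no measured data here give a reason for any of these steps.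

Still open, going by these compounds, is what sets compound 2 apart, the methylene link or the ring substituents, which plain benzyl and 4-hydroxyphenyl at the same carbon would separate. On these data alone, the part played by the methyl on the furan is also open, and unsubstituted furan-2-yl would address it.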